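The source may report more compounds than this note shows. Statements on the series, on what has been measured and on what is new or still open speak of the compounds shown alone.

Measured so far:
- compound 1, `COc1cc(-c2cc(/C=C/C(=O)c3ccc(Cl)c(Cl)c3)[nH]n2)cc(OC)c1OC`: 62%
- compound 2, `COc1ccc(-c2cc(/C=C/C(=O)c3cc(OC)c(OC)c(OC)c3)[nH]n2)cc1OC`: 51%

In a functional assay on T47D cells (Homo sapiens) for cytotoxicity, read by sulforhodamine B assay, with a stated time of 48 h, tested at 1 uM (a higher number here means a weaker effect of the compound at the concentration tested, a lower number a stronger effect), compound 1 gives 62%, the higher of the two numbers on hand. Compound 2 gives 51%, a lower reading than compound 1 by a gap that lies beyond the usual scatter, so compound 1 stands as the weaker of the two at this concentration. Among the measured compounds shown here, no pair of measured compounds differs in a single place, so no step is available to scale the next change.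

Compound 3, `COc1ccc(C(=O)/C=C/c2cc(-c3cc(OC)c(OC)c(OC)c3)n[nH]2)cc1OC`, has not been measured in this assay. It differs from compound 1 by 3,4-dimethoxyphenyl in place of 3,4-dichlorophenyl on a carbonyl carbon. The shared core and the trimethoxyphenyl on it are kept. Compound 2 carries the same dimethoxyphenyl and a trimethoxyphenyl, arranged the other way round, and its reading 51% is the only pointer to how the methoxy-bearing ring on the carbonyl side behaves. A modest downward step is expected, a number 8 percentage points lower from compound 1 to compound 3 (within the scatter), of a size near the edge of the scatter. Compound 3 is estimated at 54%, within a range from 36% to 72%.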

Compound 3, a percentage reported as activity, at one concentration (the size of the read-out at that concentration, not a potency): 75%
For compound 3 the middle estimate is 21 percentage points below the measured one; measured number above the stated range.
By their numbers in this assay, from the lowest: compound 2; then compound 1; then compound 3.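

In this assay, the aryl group on the carbonyl carbon now has its first single-place step: 3,4-dimethoxyphenyl in place of 3,4-dichlorophenyl gives a number 13 percentage points higher from compound 1 to compound 3 (beyond the scatter). The reading therefore responds to the substituents on this ring while the shared core and the trimethoxyphenyl on it stay fixed, and the swap moves the series toward a weaker effect at the concentration tested. Compound 2 differs from compound 3 in more than one place, so its reading cannot be set against this step, and no measurement at hand bears on why the step takes this direction.

One step on one pair cannot show whether the shift follows the loss of the two chlorines, the arrival of the two methoxy groups, or both together, and it gives no trend across this position. A ring on the carbonyl carbon carrying a single chlorine, a single methoxy, a dimethylamino group or a carboxylic acid would test how far the step extends, and whether any replacement for 3,4-dichlorophenyl gives a lower reading than compound 1.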